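This account rests on a few compounds, and the source may have more. Where it says the series, first, only, none or still open, it means among the compounds named here.

Measured so far:
- compound 1, `C(=C\C1CCCN(CCCOc2ccccc2)C1)\c1ccccc1`, 15 nM
- compound 2, `C=CCCCN1CCCC(/C=C/c2ccccc2)C1`, 12 nM

In an assay on isolated protein for binding affinity to Sigma non-opioid intracellular receptor 1 (Rattus norvegicus) (a higher number here means a weaker inhibitor, a lower number a stronger inhibitor), compound 2 gives 12 nM, the lowest of the two numbers in hand; its nearest neighbour is compound 1, which in this assay gives 15 nM, and the gap between the two sits within the scatter, so no order between them can be read. Both compounds share the same core, a ring amine carrying a styryl-type side arm, and differ only in what hangs from the nitrogen chain.

Compound 3, `C(=C/C1CCCN(CCCOc2ccccc2)C1)\c1ccccc1`, is not yet measured in this assay. Set against compound 2 it carries phenoxy in place of vinyl on a saturated chain carbon, three bonds along the chain from an amine nitrogen in a ring. Going by the values given here, no measured pair shows this change directly, so the size of the step has to be guessed. Among the compounds with values here, the only guidance is that compound 1, which has a phenoxy-terminated chain, and compound 2, which has the shorter open chain, give values within the scatter of each other, which argues that the exchange does not move the number much.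

Compound 3 is therefore expected to land near compound 2, at about 15 nM within 5 nM to 50 nM. The expected step of a 1.3-fold higher number from compound 2 to compound 3 (0.10 log units; within the scatter) is none beyond the scatter.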

Compound 3, half-maximal inhibitory concentration: 33 nM
Estimate against measurement, compound 3: 2.2-fold (0.34 log units) below, and the stated range covers the measured number.
By their numbers in this assay, from the lowest: compounds 2 and 1 (each within the scatter of the next); then compound 3.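

Phenoxy in place of vinyl on a saturated chain carbon, three bonds along the chain from an amine nitrogen in a ring, does move the number in this assay, with a 2.8-fold higher number from compound 2 to compound 3 (0.44 log units; beyond the scatter). Compound 1 and compound 3 have the same atoms and bonds yet also separate, with a 2.2-fold higher number from compound 1 to compound 3 (0.34 log units; beyond the scatter), so the closeness of the values of compound 1 and compound 2 cannot be taken as showing that the phenoxy exchange alone leaves the number unchanged. The double bond, drawn Z in compound 1 and E in compound 3, therefore counts in this series, and the reading of that step rests on one point: the fact that one of compounds 1 and 3 is drawn with a defined configuration and the other without, at the place where they differ

The compounds shown leave open whether a double bond drawn Z would give a step of similar size with the vinyl-ended chain of compound 2, and what the other stereo element contributes. Also open, from the compounds shown here alone, is how the number would respond to a longer chain, or to a carboxylic acid or a dimethylamino group at the chain end in place of phenoxy.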